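From pyridin-2-yl to phenyl: expectations for compound 4

The compounds below may be only part of what the source reports. "The series", "measured", "known", "first", "only" and "open" are said of these compounds alone.

Measured so far in an in vitro ADME assay on microsomes from liver (Homo sapiens) for metabolic stability, tested at 1 mg/mL (a higher number here means that the compound lasts longer, a lower number that the compound disappears faster), are three compounds:

- compound 1 `O=C(Nc1cc2cc[nH]c(=O)c2cc1Cl)C1CNCC1c1ccc(F)cc1` with 1.02 h
- compound 2 `O=C(Nc1cc2cc[nH]c(=O)c2cc1Cl)C1CNCC1c1ccccn1` with 0.967 h
- compound 3 `O=C(Nc1cc2cc[nH]c(=O)c2cc1Cl)C1CNCCC1c1ccccc1` with 0.617 h

Compound 2 lies within the scatter of both other values, so the numbers do not set it apart from either compound. The next structure, compound 4 `O=C(Nc1cc2cc[nH]c(=O)c2cc1Cl)C1CNCC1c1ccccc1`, differs from compound 2 in one place: phenyl in place of pyridin-2-yl on a saturated ring carbon. Phenyl takes the place of pyridin-2-yl on a saturated ring carbon of the five-membered non-aromatic ring with 1 nitrogen.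

The closest evidence is a 1.1-fold lower number from compound 1 to compound 2 (0.02 log units; within the scatter), a change at the same place that stays within the scatter. Compound 3 also carries phenyl, on a different saturated ring, and gives 0.617 h. On this evidence, no change beyond the scatter is expected in this assay. The estimated step is a 1.1-fold lower number from compound 2 to compound 4 (0.03 log units; within the scatter), which would remain within the scatter. Compound 4 is expected to give 0.9 h, with an estimated range from 0.5 h to 1.6 h.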

Compound 4, half-life: 2.17 h
The estimate for compound 4 lay 2.4-fold (0.38 log units) below the measured number; the whole stated range lies below it.
By their numbers in this assay, from the lowest: compounds 3, 2 and 1 (each within the scatter of the next); then compound 4.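

In this assay, this saturated ring carbon, two ring bonds from the ring nitrogen, proves sensitive to the exact aromatic group it carries: phenyl in place of pyridin-2-yl gives a 2.2-fold higher number from compound 2 to compound 4 (0.35 log units; beyond the scatter), a step the earlier pair did not foreshadow. Hydrogen in place of fluoro on an aromatic carbon gives a 2.1-fold higher number from compound 1 to compound 4 (0.33 log units; beyond the scatter), so the unsubstituted phenyl stands apart from both 4-fluorophenyl and pyridin-2-yl, which remain within the scatter of each other. Nothing shown here accounts for either step.

The compounds shown leave open whether the higher number is specific to unsubstituted phenyl or would also hold for a saturated group such as cyclohexyl. They also leave open how a methoxy group or a chlorine on the phenyl ring, or a pyridin-3-yl group, would fare at this place.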